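This account rests on a few compounds, and the source may have more. Where it says the series, first, only, none or still open, it means among the compounds named here.

In a functional assay on MCF7 cells (Homo sapiens) for cytotoxicity, read by MTT assay, with a stated time of 48 h (a higher number here means a weaker inhibitor, a lower number a stronger inhibitor), the two measured compounds stand as follows:

Compound 1 `Cc1ccc(NC(=O)N(Cc2ccccn2)n2cnnc2)cc1`: 38900 nM
Compound 2 `Cc1ccsc1CN(C(=O)Nc1ccc(Cl)c(C(F)(F)F)c1)n1cnnc1`: 30100 nM

Compound 1 and compound 2 lie within the scatter of each other in this assay, so neither stands apart from the other. Compound 3 `O=C(Nc1ccccc1)N(Cc1ccccn1)n1cnnc1` differs from compound 1 by hydrogen in place of methyl on an aromatic carbon. Among the measured compounds shown here, no measured pair shows this change, so its size is unknown; a shift beyond the scatter is not expected in either direction. Compound 3 is therefore estimated at 38900 nM in this assay, with a range from 15000 nM to 95000 nM, an expected step of no change at the digits printed from compound 1 to compound 3 (within the scatter).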

Compound 3, half-maximal inhibitory concentration: > 50000 nM
Compound 3 gave a limit, no number; the forecaster's own chance of this, stated with the estimate: 15%; middle value at least 1.2-fold (0.10 log units) away from the limit.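

In this assay compound 3 gives > 50000 nM, which is a limit and not a number. The change from 4-methylphenyl to phenyl, the first one-place change seen here, gives an at least 1.2-fold higher number from compound 1 to compound 3 (0.10 log units; that floor lies within the scatter), so hydrogen in place of methyl on this aromatic carbon brings no lower number. The step can be read only as a floor because compound 3 sits at a limit: the limit of > 50000 nM in this assay, at which 1 of the 3 values shown sits.

As far as these compounds go, whether the true step goes beyond the scatter stays open. So does how a methoxy group, an amine or a longer chain at this carbon would compare with the methyl of compound 1.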